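The compounds below may be only part of what the source reports. "The series", "measured", "known", "first", "only" and "open" are said of these compounds alone.

Compound 1 `O=C(Nc1ccccc1)c1cccc(/C=C2\CC(=O)N(c3ccccc3)C2=O)c1`, compound 2 `CCCCCN1C(=O)C/C(=C\c2cccc(C(=O)Nc3cccc(CC)c3)c2)C1=O` and compound 3 `CCCCNC(=O)c1cccc(/C=C2\CC(=O)N(Cc3ccccc3)C2=O)c1` have been measured in an ADME assay on HCT-116 cells (Homo sapiens) for cytotoxicity, read by MTT assay, with a stated time of 72 h; a lower number here means a stronger inhibitor, a higher number a weaker inhibitor.

Compound 1 gives only a limit in this assay, namely > 100000 nM. Compound 2 gives 75300 nM in this assay, and compound 3 gives 95100 nM. Compound 1 stands at the limit of > 100000 nM in this assay, at which 1 of the 3 values shown sits, so it has no number of its own to set against compound 2 and compound 3.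

Compound 4 `CCOc1ccc(NC(=O)c2cccc(/C=C3\CC(=O)N(c4ccccc4)C3=O)c2)cc1` differs from compound 1 by ethoxy in place of hydrogen on an aromatic carbon. For the measured compounds named here, no measured pair shows this change, and every number seen so far sits in the weak region, so the step of an at least 1.1-fold lower number from compound 1 to compound 4 (0.04 log units; that floor lies within the scatter) is expected to stay within the scatter, with a fair chance that compound 4 again yields only a limit. Compound 4 is expected to give about 90000 nM, between 40000 nM and 200000 nM.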

Compound 4, half-maximal inhibitory concentration: 84800 nM
Beside the measured number, compound 4's estimate is 1.1-fold (0.03 log units) above it, within the range that was stated.
By their numbers in this assay, from the lowest: compounds 2, 4 and 3 (each within the scatter of the next). At a limit, above all of these: compound 1.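

In this assay, the change from phenyl to 4-ethoxyphenyl gives an at least 1.1-fold lower number from compound 1 to compound 4 (0.07 log units; that floor lies within the scatter), a floor rather than a measured size. Compound 4 has a number of its own, 84800 nM, so ethoxy at this place leaves the compound in the same weak region while giving a value that can be read. Compound 1 remains a limit: the limit of > 100000 nM in this assay, at which 1 of the 4 values shown sits.

Going by these compounds, whether an amine or a carboxylic acid on this same carbon, or a longer chain in place of ethoxy, would give a much lower number stays open. The compounds shown also do not tell how ethoxy would behave on another carbon of this ring.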